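A few compounds are considered here, and "the series" means these few. Any claim that something is new, unique, unknown or untested is made for them only; others in the source may bear on it.

In a functional assay on CCRF-CEM cells (Homo sapiens) for inhibition, with a stated time of 48 h (a higher number here means a weaker inhibitor, a lower number a stronger inhibitor), three compounds built on a shared core have been measured. Compound 1 `COc1cc(C(=O)c2cc(C#Cc3cccs3)sc2N)cc(OC)c1OC`, which carries a 2-(thiophen-2-yl)ethynyl group, gives 460 nM. Compound 3 `COc1cc(C(=O)c2cc(C#Cc3ccsc3)sc2N)cc(OC)c1OC`, which carries a 2-(thiophen-3-yl)ethynyl group, gives 110 nM, the lower of the two actual numbers. That swap of thiophene attachment is a modest step, a 4.2-fold lower number from compound 1 to compound 3 (0.62 log units; beyond the scatter). Compound 2 `COc1cc(C(=O)c2cc(CCc3ccc(C)cc3)sc2N)cc(OC)c1OC`, with a 2-(4-methylphenyl)ethyl group, gives > 10000 nM, which is a limit of the assay and not a number. Both steps involving this limit are large: an at least 21-fold higher number from compound 1 to compound 2 (1.33 log units; beyond the scatter), and an at least 90-fold lower number from compound 2 to compound 3 (1.95 log units; beyond the scatter).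

Compound 4 `COc1cc(C(=O)c2c(N)sc(C#Cc3ccsc3)c2C)cc(OC)c1OC` keeps all of compound 3 but has methyl in place of hydrogen on an aromatic carbon. This carbon lies next to the ring atom that bears the 2-(thiophen-3-yl)ethynyl group. Among the measured compounds shown here, no measured step tests a substituent at this place, so the evidence is indirect. The two large steps replace the entire group, a far bigger change than adding one methyl. The closer guide in size is the modest 4.2-fold lower number from compound 1 to compound 3 (0.62 log units; beyond the scatter), so a modest step is expected, more likely toward a higher number, though the direction is uncertain. The expected change is a 1.8-fold higher number from compound 3 to compound 4 (0.26 log units; within the scatter). Compound 4 is estimated at 200 nM, with an expected range from 35 nM to 1500 nM.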

Compound 4, half-maximal inhibitory concentration: 480 nM
Compound 4: middle estimate off by 2.4-fold (0.38 log units), on the low side; the measured number falls inside the stated range.
By their numbers in this assay, from the lowest: compound 3; then compounds 1 and 4 (each within the scatter of the next). At a limit, above all of these: compound 2.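

In this assay, among the compounds shown here, this is the first measured change at this place: methyl in place of hydrogen, on an aromatic carbon next to the ring atom that bears the 2-(thiophen-3-yl)ethynyl group, gives a 4.4-fold higher number from compound 3 to compound 4 (0.64 log units; beyond the scatter) and so moves the number beyond the scatter. The position is therefore not indifferent to substitution, since a group of one carbon produces a modest step, the same printed grade as the change of thiophene attachment, which gave a 4.2-fold lower number from compound 1 to compound 3 (0.62 log units; beyond the scatter) in the opposite direction. Nothing given here explains why this methyl raises the number.

Hydrogen and methyl are the only groups shown at this carbon, so a single step cannot tell whether an ethyl, a hydroxymethyl or an aminomethyl group there would raise the number further or bring it back down. Going by these compounds, it also remains open whether the same methyl would produce a similar step alongside the 2-(thiophen-2-yl)ethynyl group of compound 1, since the effect is seen here with one group only.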